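The compounds below may be only part of what the source reports. "The series", "measured", "known", "first", "only" and "open" are said of these compounds alone.

Measured so far in an ADME assay on HEK-293T cells (Homo sapiens) for inhibition, read by CCK-8 assay, with a stated time of 48 h, tested at 20 uM; on this read-out lower numbers stand for less inhibition of growth and higher numbers for more inhibition of growth at the one concentration tested:
- compound 1 `Cc1ccc(S(=O)(=O)Oc2ccccc2/C=C(\C#N)C(=O)Nc2nnc(Cc3ccccc3)s2)cc1`: 15%
- compound 2 `N#C/C(=C\c1ccccc1OS(=O)(=O)c1ccc([N+](=O)[O-])cc1)C(=O)Nc1nnc(Cc2ccccc2)s1`: "not toxic" (no number reported)
- compound 3 `N#C/C(=C\c1ccccc1OS(=O)(=O)c1ccc(Cl)cc1)C(=O)Nc1nnc(Cc2ccccc2)s1`: 25%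

Compound 2 has no single number, so it cannot be ranked against the other two. The next structure is compound 4 `N#C/C(=C\c1ccccc1OS(=O)(=O)c1ccc([N+](=O)[O-])cc1)C(=O)Nc1nnc(Cc2ccc(Cl)cc2)s1`, and the change from compound 2 is chloro in place of hydrogen on an aromatic carbon, which turns benzyl into 4-chlorobenzyl. Among the compounds with values here, no measured step covers this change. The closest is a number 10 percentage points higher from compound 1 to compound 3 (within the scatter), but that step puts chloro in place of methyl, not hydrogen, and at another site in the molecule. It is therefore only weak guidance. On that step, no change beyond the scatter is expected in this assay in either direction, although without a number for compound 2 the step itself cannot be calculated. The expectation for the level rests on compound 1 at 15% and compound 3 at 25%. For compound 4 the expected value is 20%, with an estimated range from 3% to 45%.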

Compound 4, percent growth inhibition at one concentration: 19%
Estimate against measurement, compound 4: 1 percentage points above; the measured number falls inside the stated range.
By their numbers in this assay, from the lowest: compounds 1, 4 and 3 (each within the scatter of the next).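

In this assay, within the data shown here, compound 2 stands as "not toxic" (no number reported) and compound 4 gives 19% so no step between compound 2 and compound 4 can be read. The compounds shown leave open whether benzyl to 4-chlorobenzyl alters growth inhibition. Nothing shown bears on a cause for these values.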